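Benzyl swap on the shared core: cytotoxicity notes

The source may hold more compounds than are shown below. What is called first, only, known or untested is meant among the compounds shown, and "the series" means these compounds.

Values in an ADME assay on NIH3T3 cells (Mus musculus) for cytotoxicity, with a stated time of 72 h; a lower number here means a stronger inhibitor, a higher number a weaker inhibitor:
- compound 1 `OC[C@H]1O[C@@H](n2cnc3c(NCc4ccc(Br)cc4)ncnc32)[C@H](O)[C@@H]1O`: > 166000 nM (a limit)
- compound 2 `COc1cccc(CNc2ncnc3c2ncn3[C@@H]2O[C@H](CO)[C@@H](O)[C@H]2O)c1`: > 166000 nM (a limit)
- compound 3 `OC[C@H]1O[C@@H](n2cnc3c(NCc4ccc(Cl)c(Cl)c4)ncnc32)[C@H](O)[C@@H]1O`: "not determined" (no result reported)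

Compound 3 has no number, so it offers no starting value. Compound 1 and compound 2 both rest on (the limit of > 166000 nM in this assay, at which 2 of the 3 values shown sit). The change to compound 4 `OC[C@H]1O[C@@H](n2cnc3c(NCc4ccc(F)cc4F)ncnc32)[C@H](O)[C@@H]1O` is 2,4-difluorophenyl in place of 3,4-dichlorophenyl on a saturated chain carbon bound to a nitrogen on an aromatic ring. For the measured compounds named here, the only measured step is a step that the two limits leave unreadable from compound 1 to compound 2, so it gives no size to carry over. Given (the limit of > 166000 nM in this assay, at which 2 of the 3 values shown sit), no step beyond the scatter is expected in this assay, and a further limit is the likeliest result. The expected value for compound 4 is 166000 nM, with an estimated range of 50000 nM to 300000 nM.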

Compound 4, half-maximal inhibitory concentration: > 166000 nM
Compound 4 was reported as a limit; the forecaster's own chance of this, stated with the estimate: 80%; the middle value sits exactly at the limit.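

In this assay compound 4 gives > 166000 nM, a limit, so the steps to it from compound 1 and compound 2 cannot be read: the limit of > 166000 nM in this assay, at which 3 of the 4 values shown sit.

The compounds shown leave open how compound 1, compound 2 and compound 4 rank against one another, and where compound 3 stands.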